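The source may report more compounds than this note shows. Statements on the series, on what has been measured and on what is new or still open speak of the compounds shown alone.

Compounds measured so far:
compound 1 `N#Cc1c(N)nc(SCc2nc3ccccc3[nH]2)c(C#N)c1-c1ccc(OCC2CC2)cc1`: 1%
compound 2 `N#Cc1c(N)nc(SCc2cnc[nH]2)c(C#N)c1-c1ccc(OCC2CC2)cc1`: 1%

In an assay on CHO cells for displacement of a labelled ligand from adenosine receptor A3 (Homo sapiens), read by scintillation counting, with a stated time of 120 min, tested at 1 uM (a higher number here means more inhibition at the concentration tested (going by the name of the read-out), a lower number less inhibition), compound 1 gives 1% and compound 2 gives 1%. The step of no change at the digits printed from compound 1 to compound 2 (within the scatter) lies within the scatter, so compound 2 stands level with compound 1 on the numbers shown. Compound 3 `COC(=O)CSc1nc(N)c(C#N)c(-c2ccc(OCC3CC3)cc2)c1C#N` remains to be measured. It differs from compound 2 as follows: methoxycarbonyl in place of 1H-imidazol-5-yl on a saturated chain carbon bound to a sulfur. Among the measured compounds shown here, the only measured step at the same place, no change at the digits printed from compound 1 to compound 2 (within the scatter), showed no change beyond the scatter, so no step beyond the scatter is expected here either, a number 2 percentage points higher from compound 2 to compound 3 (within the scatter). Compound 3 is therefore estimated at 3%, with a range from -8% to 15%.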

Compound 3, a percentage reported as inhibition, at one concentration (the size of the read-out at that concentration, not a potency): 1%
Compound 3: the middle estimate sits 2 percentage points above what was measured; measured number inside the range.
By their numbers in this assay, from the lowest: compounds 1, 2 and 3 (each within the scatter of the next).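

In this assay, exchanging 1H-imidazol-5-yl for methoxycarbonyl on a saturated chain carbon bound to a sulfur shows no change at the digits printed from compound 2 to compound 3 (within the scatter), and exchanging 1H-benzimidazol-2-yl for the same group shows no change at the digits printed from compound 1 to compound 3 (within the scatter). Among these three compounds, then, a group with no ring and no hydrogen-bond donor reads the same as the two ring-bearing groups. Nothing available accounts for this result. Going by these compounds, it remains open whether an amine, a carboxylic acid or a longer chain at this place would give a reading beyond the scatter.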